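A few compounds are considered here, and "the series" means these few. Any claim that something is new, unique, unknown or untested is made for them only; others in the source may bear on it.

Measured compounds:
- compound 1 `CCC(C)O[C@@H]1C[C@@H]2[C@H]([C@]1(N)C(=O)O)[C@@]2(F)C(=O)O`: 6.68 nM
- compound 2 `N[C@]1(C(=O)O)[C@H]2[C@@H](C[C@H]1OCc1ccccc1Cl)[C@]2(F)C(=O)O`: 4.99 nM
- compound 3 `N[C@]1(C(=O)O)[C@H]2[C@@H](C[C@H]1OCc1cccc(Oc3ccccc3)c1)[C@]2(F)C(=O)O`: 7.15 nM

All three were tested in an assay on CHO cells for binding affinity to metabotropic glutamate receptor 2 (Rattus norvegicus); a lower number here means a stronger inhibitor, a higher number a weaker inhibitor. Compound 1 gives 6.68 nM, compound 2 gives 4.99 nM, and compound 3 gives 7.15 nM. The three numbers sit close together, each within the usual scatter of the other two, so compound 2 is not set apart from compound 1 or compound 3 on these data; the three compounds can be treated as indistinguishable in this assay.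

The shared core carries an ether whose far end differs: a sec-butyl group in compound 1, a 2-chlorophenyl in compound 2 and a 3-phenoxyphenyl in compound 3. Compound 4 `Nc1cccc(CO[C@@H]2C[C@@H]3[C@H]([C@]2(N)C(=O)O)[C@@]3(F)C(=O)O)c1` keeps the core of compound 2 and changes the far end of the ether: 3-aminophenyl in place of 2-chlorophenyl on a saturated chain carbon bound to an oxygen on a saturated carbon. Among the compounds with values here, no step between measured compounds matches this change, so there is no direct precedent to lean on. Because compound 1, compound 2 and compound 3 all land within the scatter despite carrying three quite different groups at the same place, the expectation for this assay is a step of no more than the scatter in either direction, with some added uncertainty since a hydrogen-bond donor enters where none stood before.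

Compound 4 is therefore expected to give about 7 nM, with a range from 2.5 nM to 25 nM, which corresponds to an estimated step of a 1.4-fold higher number from compound 2 to compound 4 (0.15 log units; within the scatter).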

Compound 4, inhibition constant: 15.4 nM
For compound 4 the middle estimate is 2.2-fold (0.34 log units) below the measured one, and the stated range covers the measured number.
By their numbers in this assay, from the lowest: compounds 2, 1 and 3 (each within the scatter of the next); then compound 4.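

In this assay, within the data shown here, the far end of the ether had so far taken very different groups with no separation beyond the scatter, so the position looked tolerant, but compound 4 now stands apart from that group. Putting 3-aminophenyl in place of 2-chlorophenyl on a saturated chain carbon bound to an oxygen on a saturated carbon gives a 3.1-fold higher number from compound 2 to compound 4 (0.49 log units; beyond the scatter), while amino in place of phenoxy on an aromatic carbon gives a 2.2-fold higher number from compound 3 to compound 4 (0.33 log units; beyond the scatter), and both are modest steps beyond the scatter. The position is therefore not indifferent to what it carries, although the change costs little, as compound 4 still gives 15.4 nM.

Nothing available here explains why the number rises for compound 4. From the compounds shown here alone, it also remains open whether the amino group itself drives the step, since a hydroxyl or a methoxy in place of amino on an aromatic carbon would show whether other small groups behave the same way, and the step from compound 2 also removes a chlorine.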